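The source may hold more compounds than are shown below. What is called first, only, known or untested is meant among the compounds shown, and "the series" means these compounds.

Two compounds share one core and differ only in the group sitting on a saturated chain carbon bound to an aromatic carbon. Compound 1 `Cc1nnc(CN(C)C)n1-c1ccc(Cl)cc1C(=O)c1ccccc1` carries dimethylamino there, and in a functional assay on the whole organism (strain CF-1) for positive allosteric modulation, with Mus musculus as the target (on this read-out higher numbers stand for an effect only at larger amounts of compound and lower numbers for an effect already at smaller amounts), compound 1 gives 1.1 mg/kg. Compound 2 `Cc1nnc(CN2CCCC2)n1-c1ccc(Cl)cc1C(=O)c1ccccc1` carries pyrrolidin-1-yl in that place, and in this assay compound 2 gives 1.8 mg/kg. The step of a 1.6-fold higher number from compound 1 to compound 2 (0.21 log units; within the scatter) shows that this exchange left the read-out within the usual scatter. Among the measured compounds shown here, compound 2 stands at the upper end of the two measured numbers, with compound 1 as its only neighbour at a distance that lies within the scatter, so no order between them can be claimed.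

Compound 3 `CNCc1nnc(C)n1-c1ccc(Cl)cc1C(=O)c1ccccc1` is not yet measured. Its difference from compound 2 is methylamino in place of pyrrolidin-1-yl on a saturated chain carbon bound to an aromatic carbon. For the measured compounds named here, the one measured step that bears on this change is a 1.6-fold higher number from compound 1 to compound 2 (0.21 log units; within the scatter), where swapping one group for another on that same carbon moved the number very little. Going by the values given here, no measured step covers the loss of the ring together with the arrival of a hydrogen-bond donor, so the expectation rests on that single step alone. The step expected is a 1.3-fold lower number from compound 2 to compound 3 (0.11 log units; within the scatter), that is, nothing beyond the scatter. Compound 3 is estimated at 1.4 mg/kg, with a range from 0.5 mg/kg to 4 mg/kg.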

Compound 3, dose for half-maximal effect: 2 mg/kg
Compound 3: the middle estimate sits 1.4-fold (0.15 log units) below what was measured; the measured number falls inside the stated range.
By their numbers in this assay, from the lowest: compounds 1, 2 and 3 (each within the scatter of the next).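

In this assay, replacing pyrrolidin-1-yl with methylamino on a saturated chain carbon bound to an aromatic carbon gives a 1.1-fold higher number from compound 2 to compound 3 (0.05 log units; within the scatter) and stays within the scatter, so at this position the read-out does not separate a group with a five-membered ring from a smaller open one that brings a hydrogen-bond donor. The hydrogen in place of methyl on an amine nitrogen gives a 1.8-fold higher number from compound 1 to compound 3 (0.26 log units; within the scatter), also within the scatter, which means that the dimethylamino, pyrrolidin-1-yl and methylamino compounds cannot be put in any order and that this position has so far tolerated all three amines in this whole-animal test. The data offer no measurement that could explain this flat picture.

On these data alone, all three compounds still carry an amine nitrogen on that carbon, so it remains open whether a hydroxyl group, an amide or a plain methyl chain end would give a number in the same range. Also open, as far as these compounds go, is how far the amine itself can grow, for instance to a piperidine, a morpholine or a diethylamino group, before the dose needed for the effect moves beyond the scatter.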